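The source may hold more compounds than are shown below. What is called first, only, known or untested is meant among the compounds shown, and "the series" means these compounds.

- compound 1 `CCCCN1CCN(CCCCn2c3c(c4ccccc42)C(=O)c2c[n+]([O-])c4ccccc4c2C3=O)CC1`: 1920 nM
- compound 2 `CCCN1CCN(CCCCn2c3c(c4ccccc42)C(=O)c2c[n+]([O-])c4ccccc4c2C3=O)CC1`: 790 nM

In a functional assay on HCT-116 cells (Homo sapiens) for cytotoxicity, read by MTT assay, with a stated time of 72 h (a higher number here means a weaker inhibitor, a lower number a stronger inhibitor), compound 2 has the lower of the two numbers. Compound 3 `CN1CCN(CCCn2c3c(c4ccccc42)C(=O)c2c[n+]([O-])c4ccccc4c2C3=O)CC1` differs from it as follows: 4-methylpiperazin-1-yl in place of (4-propylpiperazin-1-yl)methyl on a saturated chain carbon, three bonds along the chain from an aromatic nitrogen. Going by the values given here, only one measured step bears on this change: a 2.4-fold lower number from compound 1 to compound 2 (0.39 log units; beyond the scatter), a modest step that came with hydrogen in place of methyl on a saturated chain carbon. Compound 2 therefore suggests a further modest step towards a lower number, though this single step is weak evidence. The expected change is a 2.1-fold lower number from compound 2 to compound 3 (0.32 log units; beyond the scatter). For compound 3, the estimated value is 380 nM, with an expected range of 130 nM to 1100 nM.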

Compound 3, half-maximal inhibitory concentration: 560 nM
For compound 3 the middle estimate is 1.5-fold (0.17 log units) below the measured one; measured number inside the range.
By their numbers in this assay, from the lowest: compounds 3 and 2 (each within the scatter of the next); then compound 1.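

In this assay, putting 4-methylpiperazin-1-yl in place of (4-propylpiperazin-1-yl)methyl on this saturated chain carbon gives a 1.4-fold lower number from compound 2 to compound 3 (0.15 log units; within the scatter), so this change does not separate the two. Measured against the (4-butylpiperazin-1-yl)methyl group, the same kind of replacement gives a 3.4-fold lower number from compound 1 to compound 3 (0.54 log units; beyond the scatter), a step that does stand out. No measurement at hand accounts for these numbers. From the compounds shown here alone, whether a morpholine, a piperazine with hydrogen on its nitrogen or a longer chain would shift the number remains open.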